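From compound 2 to compound 4: a longer chain

The compounds below may be only part of what the source reports. "The series", "measured", "known", "first", "only" and "open" are said of these compounds alone.

Within the data shown here, in a functional assay on DU-145 cells (Homo sapiens) for cytotoxicity, read by MTT assay, with a stated time of 24 h (on this read-out higher numbers stand for weaker inhibition and lower numbers for stronger inhibition), compound 1 (`CCCCCCCCCCCC(=O)Nc1nnc(S[C@@H]2O[C@H](COC(C)=O)[C@H](OC(C)=O)[C@H](OC(C)=O)[C@H]2OC(C)=O)s1`) gives 16900 nM and is the only tested compound with a number. Compound 2 (`CCCCCCCCCC(=O)Nc1nnc(S[C@@H]2O[C@H](CO)[C@H](O)[C@H](O)[C@H]2O)s1`) is recorded as "not active" (no number reported) in this assay and therefore has no single number to mark its place. Compound 3 (`CCCCCC(=O)Nc1nnc(S[C@@H]2O[C@H](COC(C)=O)[C@H](OC(C)=O)[C@H](OC(C)=O)[C@H]2OC(C)=O)s1`) shares that position and is recorded as "not active" (no number reported) in this assay as well.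

Compound 4 (`CCCCCCCCCCCCCCCC(=O)Nc1nnc(S[C@@H]2O[C@H](CO)[C@H](O)[C@H](O)[C@H]2O)s1`) has not yet been measured. The structural change is hexyl in place of hydrogen on a saturated chain carbon, nine bonds along the chain from a carbonyl carbon and lengthens the chain, which read one bond further out is methyl to heptyl. Among the measured compounds shown here, no measured pair shows the size of such a change, so any step remains an expectation. A modest step towards stronger inhibition is expected, from no reported number to a weak measurable value, although another result without a number remains quite possible. For the measured compounds named here, compound 1 at 16900 nM is the only guide to where such a value might lie. For compound 4 the estimated value is 25000 nM with an expected range of 8000 nM to 80000 nM in this assay.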

Compound 4, half-maximal inhibitory concentration: "not active" (no number reported)
No number was reported for compound 4; no gap can be computed for the estimate.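

Compound 2 and compound 4 are both recorded as "not active" in this assay, and no step can be read between them. Nothing measured here speaks to this outcome. The compounds shown leave open whether lengthening the chain changes the read-out at all.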